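Thioamide for nitrile on two nucleoside cores

This account rests on a few compounds, and the source may have more. Where it says the series, first, only, none or still open, it means among the compounds named here.

Measured compounds:
compound 1, `N#Cc1cn(C2OC(CO)CC2O)c2ncnc(N)c12`, 4000 nM
compound 2, `N#Cc1cn(C2C=CC(CO)O2)c2ncnc(N)c12`, 176000 nM
compound 3, `NC(=S)c1cn(C2OC(CO)CC2O)c2ncnc(N)c12`, 3000 nM

In a functional assay on KB cells (Homo sapiens) for inhibition (a higher number here means a weaker inhibitor, a lower number a stronger inhibitor), compound 1 gives 4000 nM, and compound 3 gives 3000 nM. The change between them is a group of 3 heavy atoms (1 carbon, 1 nitrogen, 1 sulfur; no ring) in place of a group of 2 heavy atoms (1 carbon, 1 nitrogen; no ring), on an aromatic carbon, and it made a 1.3-fold lower number from compound 1 to compound 3 (0.12 log units; within the scatter). Compound 2 carries a different core; the difference between the two cores is not broken down here. Compound 2 gives 176000 nM, the highest of the three numbers.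

Compound 4, `NC(=S)c1cn(C2C=CC(CO)O2)c2ncnc(N)c12`, has not been measured. It differs from compound 2 by a group of 3 heavy atoms (1 carbon, 1 nitrogen, 1 sulfur; no ring) in place of a group of 2 heavy atoms (1 carbon, 1 nitrogen; no ring), on an aromatic carbon, the same kind of change as that from compound 1 to compound 3. Because compound 1 to compound 3 gave a 1.3-fold lower number from compound 1 to compound 3 (0.12 log units; within the scatter), the step in this assay is expected to be a 1.3-fold lower number from compound 2 to compound 4 (0.12 log units; within the scatter). Compound 4 is therefore estimated at 135000 nM, expected between 45000 nM and 400000 nM.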

Compound 4, half-maximal inhibitory concentration: 5000 nM
Beside the measured number, compound 4's estimate is 27-fold (1.43 log units) above it; the whole stated range lies above it.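

On the core of compound 2, the thioamide in place of the nitrile gave a 35-fold lower number from compound 2 to compound 4 (1.55 log units; beyond the scatter) in this assay. The size of this change did not carry over from one core to the other: the same change on two cores in this assay, a 1.3-fold lower number (0.12 log units; within the scatter) from compound 1 to compound 3 and a 35-fold lower number (1.55 log units; beyond the scatter) from compound 2 to compound 4, 26-fold (1.42 log units) apart, beyond the scatter of two such steps. With one pair on each core, this shows that the step depends on the core in these four compounds, but it does not show which feature of the core is responsible or how the step would run on a third core.

The compounds shown leave open whether a primary amide or a carboxylic acid on the same aromatic carbon would follow the thioamide on either core. They also leave open which of the two steps a third core would resemble.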